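Swapping a pyridine for a methylphenyl on an imidazoline ether

The source may report more compounds than this note shows. Statements on the series, on what has been measured and on what is new or still open speak of the compounds shown alone.

Compound 1 has the structure `CC(Oc1ccccc1-c1ccncc1)C1=NCCN1`. In a functional assay on CHO cells for agonist activity at Alpha-2C adrenergic receptor (Homo sapiens) (on this read-out lower numbers stand for smaller maximal responses and higher numbers for larger maximal responses), compound 1 reaches only a limit, < 0.3, rather than a measured number. A second compound, compound 2, has the structure `CC(Oc1ccccc1-c1ccccc1)C1=NCCO1`. In this assay compound 2 likewise stops at a limit of < 0.3. Both values sit at the limit of < 0.3 in this assay, at which 2 of the 2 values shown sit, so neither compound gives a measurable maximal response on its own, and compound 1 cannot be placed above or under compound 2 from these numbers.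

Compound 3, with the structure `Cc1cccc(-c2ccccc2OC(C)C2=NCCN2)c1`, has not yet been tested. It differs from compound 1 in one place: 3-methylphenyl in place of pyridin-4-yl on an aromatic carbon.

Going by the values given here, no measured pair of compounds that differ in one place is available, so the size of this step can only be estimated. Among the compounds with values here, both compounds measured so far, compound 1 and compound 2, sit at a limit, so the step from compound 1 to compound 3 in this assay is expected to be small, a step that the limit leaves unreadable from compound 1 to compound 3, and compound 3 is estimated to give 0.2, between 0 and 0.45.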

Compound 3, intrinsic activity: the largest response reached, as a fraction of the reference agonist's: 0.6
Estimate against measurement, compound 3: 0.40 below; measured number above the stated range.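

In this assay, the group on an aromatic carbon, ortho to a group of 8 heavy atoms, clearly matters for the maximal response: 3-methylphenyl in place of pyridin-4-yl gives a number at least 0.30 higher from compound 1 to compound 3 (beyond the scatter). Compound 3, at 0.6, is the only compound shown with a measured number, so the core it shares with compound 1 can give a readable maximal response when it carries this group. The size of the step is a minimum and not an exact figure, because compound 1 stands at a limit: the limit of < 0.3 in this assay, at which 2 of the 3 values shown sit.

This one change removes the ring nitrogen and adds a methyl group at once, so the compounds shown cannot tell which of the two goes with the larger response. A plain phenyl on the core of compound 1 would separate these two parts of the change, while a 4-methylphenyl or a 3-methoxyphenyl would show whether the methyl group's place on the ring, or the methyl group itself, counts.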